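The source may hold more compounds than are shown below. What is called first, only, known or untested is meant among the compounds shown, and "the series" means these compounds.

Compound 1 `Cc1cc(Nc2cc(N3CCN(C)CC3)nc(Nc3ccc([N+](=O)[O-])cc3)n2)n[nH]1`: 1630 nM
Compound 2 `Cc1cc(Nc2cc(N3CCN(C)CC3)nc(Nc3ccc(Cl)cc3)n2)n[nH]1`: 1370 nM
Compound 3 `COc1cccc(Nc2nc(Nc3cc(C)[nH]n3)cc(N3CCN(C)CC3)n2)c1`: 923 nM

These values come from a functional assay on HCT-116 cells (Homo sapiens) for antiproliferative activity, read by CCK-8 assay, with a stated time of 72 h; a lower number here means a stronger inhibitor, a higher number a weaker inhibitor. Compound 3, at 923 nM, cannot be separated from the other two compounds, since every step among the three lies within the scatter. The next compound, compound 4 `Cc1cc(Nc2cc(N3CCN(C)CC3)nc(Nc3cccc([N+](=O)[O-])c3)n2)n[nH]1`, keeps the 3-substituted phenyl of compound 3 but carries nitro in place of methoxy on an aromatic carbon, meta to a large group: nitro in place of methoxy on an aromatic carbon. Within the data shown here, no measured step makes exactly this exchange. The closest is a 1.8-fold lower number from compound 1 to compound 3 (0.25 log units; within the scatter), where 3-methoxyphenyl takes the place of 4-nitrophenyl. Also relevant is a 1.2-fold lower number from compound 1 to compound 2 (0.08 log units; within the scatter), where chloro takes the place of nitro, and a 1.5-fold lower number from compound 2 to compound 3 (0.17 log units; within the scatter) completes the set. As none of these steps exceeds the scatter, no change beyond the scatter is expected in this assay, with at most a slight drift towards compound 1, which gives 1630 nM. The expected change is a 1.4-fold higher number from compound 3 to compound 4 (0.15 log units; within the scatter). For compound 4 the estimated value is 1300 nM, with an expected range of 700 nM to 2400 nM.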

Compound 4, half-maximal inhibitory concentration: 1820 nM
For compound 4 the middle estimate is 1.4-fold (0.15 log units) below the measured one; low and high end bracket the measured number.
By their numbers in this assay, from the lowest: compounds 3, 2, 1 and 4 (each within the scatter of the next).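

In this assay, nitro in place of methoxy on an aromatic carbon, meta to a large group, still stays within the scatter (a 2.0-fold higher number from compound 3 to compound 4 (0.29 log units; within the scatter)), so this exchange at the position cannot be told apart from no change. The place of the nitro group on the phenyl ring makes no separable difference either, with 3-nitrophenyl in place of 4-nitrophenyl (a 1.1-fold higher number from compound 1 to compound 4 (0.05 log units; within the scatter)), and the same holds for 3-nitrophenyl in place of 4-chlorophenyl (a 1.3-fold higher number from compound 2 to compound 4 (0.12 log units; within the scatter)). No supporting evidence bears on this result.

The compounds shown leave open whether an amine, a carboxylic acid or a longer chain on this phenyl ring would give a step beyond the scatter. They also leave open whether a change elsewhere on the shared core would do so.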